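Furan-2-yl in Place of Phenyl on the Amide Carbonyl

The source may report more compounds than this note shows. Statements on the series, on what has been measured and on what is new or still open speak of the compounds shown alone.

Two members of the series have numbers in an assay on isolated protein with Bile acid receptor (Homo sapiens) as the target; a lower number here means that less compound is needed, a higher number that more compound is needed for the effect. Compound 1 `COC(=O)/C=C/c1cccc(N(Cc2ccc(/C=C/c3ccccn3)cc2)C(=O)C2CCCCC2)c1` gives 309 nM in this assay. Compound 2 `COC(=O)/C=C/c1cccc(N(Cc2ccc(/C=C/C(=O)OC(C)(C)C)cc2)C(=O)c2ccccc2)c1` gives 236 nM in this assay; compound 1 with 309 nM lies within the usual scatter of that, so the two cannot be told apart on these numbers.

Compound 3 `COC(=O)/C=C/c1cccc(N(Cc2ccc(/C=C/C(=O)OC(C)(C)C)cc2)C(=O)c2ccco2)c1` has not been measured. It differs from compound 2 in one place: furan-2-yl in place of phenyl on a carbonyl carbon. Going by the values given here, no measured pair carries this or a comparable change, so nothing here shows what such a swap does to the read-out. The expectation is therefore a step from compound 2 to compound 3 of a 1.0-fold lower number from compound 2 to compound 3 (0.01 log units; within the scatter), in no direction beyond the scatter. Compound 3 is estimated to give 230 nM in this assay, with a range from 100 nM to 550 nM.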

Compound 3, half-maximal effective concentration: 205 nM
Beside the measured number, compound 3's estimate is 1.1-fold (0.05 log units) above it, within the range that was stated.
By their numbers in this assay, from the lowest: compounds 3, 2 and 1 (each within the scatter of the next).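

Going by these compounds alone, on the carbonyl carbon whose other neighbour is the amide-type nitrogen, furan-2-yl in place of phenyl provides the first one-place comparison in this assay: a 1.2-fold lower number from compound 2 to compound 3 (0.06 log units; within the scatter). At this position, a five-membered aromatic ring with 1 hetero atom and 1 hydrogen-bond acceptor therefore cannot be told apart from a six-membered aromatic ring of carbon only, on these numbers. Nothing available bears on the reason for this result.

This single pair cannot show whether the same swap gives a similar step when another part of the molecule differs. Also open, from the compounds shown here alone, is the read-out with a more distinct group on this carbonyl carbon, such as a piperidine ring carrying a basic amine or a benzoic acid with its free carboxylic acid.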